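Taking the hydroxy off compound 3

This account rests on a few compounds, and the source may have more. Where it says the series, first, only, none or still open, it means among the compounds named here.

Compound 1 `COc1cc(N2C(=O)CC2c2ccc(SC)cc2)cc(OC)c1OC`: 108 nM
Compound 2 `CCSc1ccc(C2C(Oc3ccccc3)C(=O)N2c2cc(OC)c(OC)c(OC)c2)cc1`: 632 nM
Compound 3 `CCSc1ccc(C2C(O)C(=O)N2c2cc(OC)c(OC)c(OC)c2)cc1`: 12 nM

For the measured compounds named here, in a functional assay on HT-29 cells (Homo sapiens) for inhibition, read by sulforhodamine B assay, with a stated time of 72 h (on this read-out lower numbers stand for stronger inhibition and higher numbers for weaker inhibition), compound 3 gives 12 nM, the lowest of the three numbers so far. The next compound, compound 4 `CCSc1ccc(C2CC(=O)N2c2cc(OC)c(OC)c(OC)c2)cc1`, differs from it in one place: hydrogen in place of hydroxy on a saturated ring carbon. Going by the values given here, only one measured step involves this carbon's substituent: a 53-fold lower number from compound 2 to compound 3 (1.72 log units; beyond the scatter). That step swaps phenyl for hydrogen on the oxygen, so the oxygen stays and it cannot show what losing the hydroxy does. Among the compounds with values here, it shows only that the number responds strongly to changes here. Compound 1, at 108 nM, is the closer guide, since it also has no hydroxy, although it carries a methylsulfanyl group where compound 4 has ethylsulfanyl. Within the data shown here, no measured step isolates that difference. A higher number, by a step beyond the scatter, therefore seems likely. The expected change is a 6.7-fold higher number from compound 3 to compound 4 (0.82 log units; beyond the scatter). For compound 4 the estimated value is 80 nM, with an expected range from 25 nM to 250 nM.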

Compound 4, half-maximal inhibitory concentration: 311 nM
For compound 4 the middle estimate is 3.9-fold (0.59 log units) below the measured one; the whole stated range lies below it.
By their numbers in this assay, from the lowest: compound 3; then compound 1; then compound 4; then compound 2.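

In this assay, hydrogen in place of hydroxy gives a 26-fold higher number from compound 3 to compound 4 (1.41 log units; beyond the scatter) on the saturated ring carbon, so the number depends on the hydroxy itself and not only on what is attached to its oxygen. Hydrogen in place of phenoxy gives only a 2.0-fold lower number from compound 2 to compound 4 (0.31 log units; beyond the scatter) as a modest step, which means that compound 2 and compound 4 both lie far above compound 3, whether the oxygen carries phenyl or is absent. Among the compounds without a hydroxy, the group on sulfur also counts: ethylsulfanyl in place of methylsulfanyl gives a 2.9-fold higher number from compound 1 to compound 4 (0.46 log units; beyond the scatter) as a modest step.

No measurement shown here explains why the hydroxy has such a large effect. On these data alone, whether a methoxy, an amine or a fluorine on this ring carbon could match the hydroxy remains open.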